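A few compounds are considered here, and "the series" means these few. Any claim that something is new, unique, unknown or untested is made for them only; others in the source may bear on it.

In a functional assay on HepG2 cells (Homo sapiens) for cytotoxicity, read by MTT assay, with a stated time of 24 h (a lower number here means a stronger inhibitor, a higher number a weaker inhibitor), compound 1 `Cc1ccc(S(=O)(=O)N2C/C(=C\c3ccncc3)C(=O)/C(=C/c3ccccc3F)C2)cc1` gives 9700 nM, compound 2 `Cc1ccc(S(=O)(=O)N2C/C(=C\c3cccnc3)C(=O)/C(=C/c3ccccc3C(F)(F)F)C2)cc1` gives 2930 nM and compound 3 `Cc1ccc(S(=O)(=O)N2C/C(=C\c3ccncc3)C(=O)/C(=C/c3ccccc3C(F)(F)F)C2)cc1` gives 4640 nM. Compound 3 thus lies within the scatter of compound 2 and lower than compound 1. Compound 4 `CC(=O)Nc1ccc(S(=O)(=O)N2C/C(=C\c3ccncc3)C(=O)/C(=C/c3ccccc3C(F)(F)F)C2)cc1` carries acetamido in place of methyl on an aromatic carbon, para to a large group. Among the compounds with values here, no measured step changes this group. The nearest guides are changes made elsewhere: a 2.1-fold lower number from compound 1 to compound 3 (0.32 log units; beyond the scatter) and a 1.6-fold higher number from compound 2 to compound 3 (0.20 log units; within the scatter). Both are small, so no step beyond the scatter is expected in this assay, and no direction can be supported. The expected result is a 1.2-fold higher number from compound 3 to compound 4 (0.07 log units; within the scatter). The estimate for compound 4 is 5500 nM, with an expected range of 2000 nM to 15000 nM.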

Compound 4, half-maximal inhibitory concentration: 4840 nM
For compound 4 the middle estimate is 1.1-fold (0.06 log units) above the measured one, and the stated range covers the measured number.
By their numbers in this assay, from the lowest: compounds 2, 3, 4 and 1 (each within the scatter of the next, the first and the last beyond it).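

In this assay, within the data shown here, the aromatic carbon para to a large group is changed here for the first time, and 4-acetamidophenyl in place of 4-methylphenyl gives a 1.0-fold higher number from compound 3 to compound 4 (0.02 log units; within the scatter). At this position, with pyridin-4-yl and trifluoromethyl held constant, the assay therefore tolerates acetamido, with its hydrogen-bond donor and acceptor, without a change beyond the scatter. No available evidence bears on this result.

As far as these compounds go, whether an amine, a carboxylic acid or a longer chain at this carbon would also stay within the scatter remains open. Also open, from the compounds shown here alone, is whether acetamido behaves the same way alongside pyridin-3-yl.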